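The source may report more compounds than this note shows. Statements on the series, on what has been measured and on what is new or still open speak of the compounds shown alone.

Measured so far:
compound 1, `CCCCCCCCCCCSC(=S)C1=C(Nc2ccc(Cl)cc2Cl)CC(C)(C)CC1=O`, gives > 20 ug/mL
compound 2, `CCCCSC(=S)C1=C(Nc2ccc(Br)cc2)CC(C)(C)CC1=O`, gives > 20 ug/mL

Two compounds carry a number, and neither is a true number. In a functional assay on PBMC cells (Homo sapiens) for inhibition, read by ELISA, with a stated time of 18 h (on this read-out higher numbers stand for weaker inhibition and lower numbers for stronger inhibition), compound 1 gives only a limit, > 20 ug/mL. In this assay compound 2 likewise gives only a limit, > 20 ug/mL. Compound 2 therefore stands at the limit of > 20 ug/mL in this assay, at which 2 of the 2 values shown sit, and no ordering against compound 1 can be read from this. Among the measured compounds shown here, no step between measured compounds is available.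

Compound 3, `CCCCCCCCCCCSC(=S)C1=C(Nc2ccc(Br)cc2)CC(C)(C)CC1=O`, is not yet measured in this assay. It differs from compound 2 by heptyl in place of hydrogen on a saturated chain carbon, four bonds along the chain from a sulfur. Compound 1 carries this same long chain on its sulfur, and in this assay compound 1 sits at the limit > 20 ug/mL. In this assay the expected step is a step that the limit leaves unreadable from compound 2 to compound 3, none beyond the scatter. Compound 3 is expected at 30 ug/mL, between 12 ug/mL and 80 ug/mL, most likely reported again only as a limit.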

Compound 3, half-maximal inhibitory concentration: > 20 ug/mL
Compound 3: no number, only a limit (the forecaster's own chance of this, stated with the estimate: 80%); the middle value does not contradict the limit.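

No step from compound 1 or compound 2 to compound 3 can be read, as all three give only a limit: the limit of > 20 ug/mL in this assay, at which 3 of the 3 values shown sit.

The compounds shown leave open whether heptyl in place of hydrogen, or 4-bromophenyl in place of 2,4-dichlorophenyl, changes inhibition at all in this assay.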